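Oxazole ketone series: carbamoylphenyl replacement at the aryl position

A few compounds are considered here, and "the series" means these few. Any claim that something is new, unique, unknown or untested is made for them only; others in the source may bear on it.

Measured compounds:
compound 1 `Nc1ccccc1-c1cnc(C(=O)CCCCCCc2ccccc2)o1` in an assay (Rattus norvegicus) for inhibition of Fatty-acid amide hydrolase 1 (Homo sapiens) (a higher number here means a weaker inhibitor, a lower number a stronger inhibitor), gives 750 nM
compound 2 `O=C(CCCCCCc1ccccc1)c1ncc(-c2ccccc2F)o1` gives 110 nM
compound 3 `O=C(CCCCCCc1ccccc1)c1ncc(-c2ccc(F)cc2)o1` gives 62 nM

Compound 1 gives the highest number of the three; the nearest is compound 2, reached by a 6.8-fold lower number from compound 1 to compound 2 (0.83 log units; beyond the scatter), and the furthest is compound 3, reached by a 12-fold lower number from compound 1 to compound 3 (1.08 log units; beyond the scatter). Between compound 2 and compound 3 the step is a 1.8-fold lower number from compound 2 to compound 3 (0.25 log units; within the scatter).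

Compound 4 `NC(=O)c1ccc(-c2cnc(C(=O)CCCCCCc3ccccc3)o2)cc1` is not yet measured in this assay. It differs from compound 1 as follows: 4-carbamoylphenyl in place of 2-aminophenyl on an aromatic carbon.

Within the data shown here, the steps that bear on this change are those from compound 1: both remove the 2-aminophenyl group and both gave lower numbers beyond the scatter, the larger of them being the one to the 4-fluorophenyl group, a 12-fold lower number from compound 1 to compound 3 (1.08 log units; beyond the scatter). Among the measured compounds shown here, the entering 4-carbamoylphenyl group is not represented among the measured compounds, so the size of its effect is uncertain; a carbamoyl group is not a fluoro group, and no step shows its own contribution. A lower number than compound 1 is expected, smaller than either measured step. From the compounds shown here alone, the new group is untested, and the expectation is held back on that account. The estimate for compound 4 is 250 nM, with a range of 60 nM to 1000 nM, meaning an expected step of a 3.0-fold lower number from compound 1 to compound 4 (0.48 log units; beyond the scatter).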

Compound 4, inhibition constant: 10 nM
Compound 4: the middle estimate sits 25-fold (1.40 log units) above what was measured; measured number below the stated range.
By their numbers in this assay, from the lowest: compound 4; then compounds 3 and 2 (each within the scatter of the next); then compound 1.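

In this assay, this position on the shared core allows a much lower number than the fluorophenyl compounds suggested: the 4-carbamoylphenyl group gives a 75-fold lower number from compound 1 to compound 4 (1.88 log units; beyond the scatter). The gain is more than the loss of the 2-aminophenyl group, as carbamoyl in place of fluoro gives a 6.2-fold lower number from compound 3 to compound 4 (0.79 log units; beyond the scatter), and the change from the 2-fluorophenyl group gives an 11-fold lower number from compound 2 to compound 4 (1.04 log units; beyond the scatter), so compound 4 stands beyond the scatter of all three earlier compounds. Nothing available explains this advantage of the 4-carbamoylphenyl group.

Open, from the compounds shown here alone, is whether the result depends on the carbamoyl group itself, which a 4-carboxyphenyl, 4-cyanophenyl or 4-methylcarbamoylphenyl group would test. Also open, going by these compounds, are the effect of a 2-carbamoylphenyl group and whether the step holds with a shorter or longer chain on the ketone.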